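Switching the pyridyl nitrogen once more on the styryl chain

The source may hold more compounds than are shown below. What is called first, only, known or untested is meant among the compounds shown, and "the series" means these compounds.

Compound 2 `Clc1ncc(OCC2CCCN2)cc1/C=C/c1cccnc1` gives 0.028 nM in an assay for binding affinity to Neuronal acetylcholine receptor; alpha4/beta2 (Rattus norvegicus) (on this read-out lower numbers stand for stronger inhibition and higher numbers for weaker inhibition), and it sits within the scatter of compound 1 `Clc1ncc(OCC2CCCN2)cc1/C=C/c1ccncc1`, which gives 0.015 nM. Compound 3 `Clc1ncc(OCC2CCCN2)cc1/C=C/c1ccccn1` differs from compound 2 by pyridin-2-yl in place of pyridin-3-yl on a double-bonded chain carbon bound to a double-bonded chain carbon. Going by the values given here, the only step that bears on this change is a 1.9-fold higher number from compound 1 to compound 2 (0.27 log units; within the scatter), which moved the nitrogen around the same ring without a change beyond the scatter. Compound 3 is therefore expected to show at most a small rise, a 2.1-fold higher number from compound 2 to compound 3 (0.33 log units; beyond the scatter), giving an estimated 0.06 nM with a likely range from 0.015 nM to 0.3 nM.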

Compound 3, inhibition constant: 0.331 nM
Compound 3: the middle estimate sits 5.5-fold (0.74 log units) below what was measured; measured number outside the range, above it.
By their numbers in this assay, from the lowest: compounds 1 and 2 (each within the scatter of the next); then compound 3.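

The place on the double-bonded chain carbon proves sensitive to where the ring nitrogen lies: pyridin-2-yl gives a 12-fold higher number from compound 2 to compound 3 (1.07 log units; beyond the scatter) and a 22-fold higher number from compound 1 to compound 3 (1.34 log units; beyond the scatter), whereas the earlier exchange stayed within the scatter. Among these three groups, only pyridin-2-yl stands apart. Nothing available explains this rise. The compounds shown leave open whether a plain phenyl ring in the same place would stay with compound 1 and compound 2 or rise like compound 3, and whether a methyl group on the pyridin-2-yl ring would change the number.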